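A cyano group gives way to 1,3-benzoxazol-2-yl

The source may hold more compounds than are shown below. What is called first, only, known or untested is meant among the compounds shown, and "the series" means these compounds.

In a functional assay on HeLa cells (Homo sapiens) for antiproliferative activity, read by MTT assay, with a stated time of 48 h (on this read-out higher numbers stand for weaker inhibition and lower numbers for stronger inhibition), compound 1 `N#Cc1nc2c(-c3nc4ccccc4[nH]3)c(N)n(CCO)c2nc1C#N` gives > 50000 nM as a limit and not as a number. In this assay compound 2 `CN(C)CCCCn1c(N)c(C#N)c2nc(C#N)c(C#N)nc21`, which carries a 4-(dimethylamino)butyl group, gives > 50000 nM as a limit as well. Compound 2 therefore has no number of its own, and the record so far is the limit of > 50000 nM in this assay, at which 2 of the 2 values shown sit, with no measured value beneath it.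

Compound 3 `CN(C)CCCCn1c(N)c(-c2nc3ccccc3o2)c2nc(C#N)c(C#N)nc21` keeps the 4-(dimethylamino)butyl group and the shared core of compound 2. The change 1,3-benzoxazol-2-yl in place of cyano on an aromatic carbon puts 1,3-benzoxazol-2-yl in place of cyano on an aromatic carbon, next to the ring atom that bears an amino group.

Going by the values given here, no measured step shows what such a replacement does. In this assay a step toward stronger inhibition is nevertheless expected for compound 3, though only a moderate one, and the result may stay at the limit. The estimated change is an at least 2.0-fold lower number from compound 2 to compound 3 (0.30 log units; that floor lies within the scatter) in this expectation. For compound 3 the expected value is 25000 nM within an estimated range of 6000 nM to 70000 nM.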

Compound 3, half-maximal inhibitory concentration: 1950 nM
Compound 3: middle estimate off by 13-fold (1.11 log units), on the high side; measured number outside the range, below it.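

In this assay, this carbon of the shared core is the first place shown where a change brings the read-out down from the limit, and the step is large: an at least 25-fold lower number from compound 2 to compound 3 (1.40 log units; beyond the scatter). That size is only a floor, as compound 2 has a limit and not a number, so the true distance could be greater. With the 4-(dimethylamino)butyl group kept, replacing cyano with 1,3-benzoxazol-2-yl is the only change that separates compound 3 from compound 2, and compound 3 now stands as the one measured value beneath the limit: the limit of > 50000 nM in this assay, at which 2 of the 3 values shown sit.

This single pair does not tell which feature of the entering group carries the step, whether its fused six-membered ring, its ring oxygen or its ring nitrogen. It also leaves open whether a plain phenyl group on this carbon would give a similar step, and whether 1,3-benzoxazol-2-yl would keep its effect with a morpholine in place of the dimethylamino group at the end of the chain.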